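Pyrrolidine nitrogen: methyl to oxanyl on compound 1

A few compounds are considered here, and "the series" means these few. Any claim that something is new, unique, unknown or untested is made for them only; others in the source may bear on it.

In an assay on isolated protein for binding affinity to melanin-concentrating hormone receptor 1 (Homo sapiens) (a lower number here means a stronger inhibitor, a higher number a weaker inhibitor), compound 1 `Cc1ccc(-c2cc3ncn([C@H]4CCN(C(=O)N(C)[C@H]5CCN(C)C5)C4)c(=O)c3s2)c(C)c1` gives 49 nM, the second highest of three numbers. Compound 2 `CCOc1ccc(-c2cc3ncn([C@H]4CCN(C(=O)N(C)[C@H]5CCN(C)C5)C4)c(=O)c3s2)c(Cl)c1` gives 26 nM, and a 1.9-fold lower number from compound 1 to compound 2 (0.28 log units; within the scatter) stays within the scatter. Compound 3 `CN1CC[C@H](N(C)C(=O)N2CC[C@H](n3cnc4cc(-c5ccc6c(c5)OCCO6)sc4c3=O)C2)C1` gives 143 nM; a 2.9-fold higher number from compound 1 to compound 3 (0.47 log units; beyond the scatter) and a 5.5-fold higher number from compound 2 to compound 3 (0.74 log units; beyond the scatter) are both modest. Compound 4 `Cc1ccc(-c2cc3ncn([C@H]4CCN(C(=O)N(C)[C@H]5CCN(C6CCOCC6)C5)C4)c(=O)c3s2)c(C)c1` differs from compound 1 by oxan-4-yl in place of methyl on an amine nitrogen in a ring. Within the data shown here, all three measured steps change only the aryl group on the shared core and leave the amine nitrogen in the ring untouched, so no measured step bears directly on this change. With nothing to indicate a direction, no step beyond the scatter is expected. The expected step is a 1.0-fold higher number from compound 1 to compound 4 (0.01 log units; within the scatter). Compound 4 is estimated at 50 nM, with a range from 20 nM to 125 nM.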

Compound 4, inhibition constant: 70 nM
Compound 4: the middle estimate sits 1.4-fold (0.15 log units) below what was measured; measured number inside the range.
By their numbers in this assay, from the lowest: compounds 2, 1 and 4 (each within the scatter of the next, the first and the last beyond it); then compound 3.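

Among these compounds, at the amine nitrogen in the ring, oxan-4-yl in place of methyl gives a 1.4-fold higher number from compound 1 to compound 4 (0.15 log units; within the scatter) in this assay and is the only reading here at this position, as the earlier steps change only the aryl group. The position therefore accepts oxan-4-yl, with its six heavy atoms and one hydrogen-bond acceptor, with no step beyond the scatter. No measured evidence bears on this result.

As far as these compounds go, whether an acetyl group or piperidin-4-yl at this nitrogen would also stay within the scatter remains open. So does whether oxan-4-yl behaves the same way on the aryl groups of compound 2 or compound 3.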